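The compounds below may be only part of what the source reports. "The series", "measured", "known", "first", "only" and "open" are said of these compounds alone.

Measured so far:
compound 1 `CCC(=O)Nc1cc(Nc2ncc(Br)c(Nc3ccc4cc[nH]c4c3)n2)c(OC)cc1N1CCN(C)CC1` — 4.46 h
compound 2 `C=CC(=O)Nc1cc(Nc2ncc(Br)c(Nc3ccc4ccn(C)c4c3)n2)c(OC)cc1N1CCN(C)CC1` — 3.25 h

In an ADME assay on the whole organism (Rattus norvegicus, strain Sprague-Dawley) for metabolic stability, read by LC-MS, with a stated time of 24 h, at a dose of 10 mg/kg by the oral route (on this read-out lower numbers stand for a shorter-lived compound and higher numbers for a longer-lived compound), compound 2 stands at the smaller of the two numbers, and the gap to compound 1 lies within the scatter, so the pair shows no separation. Compound 3 `C=CC(=O)Nc1cc(Nc2ncc(Br)c(Nc3ccc4c(c3)CCC4)n2)c(OC)cc1N1CCN(C)CC1` differs from compound 2 in one place: 2,3-dihydro-1H-inden-5-yl in place of 1-methyl-1H-indol-6-yl on a nitrogen on an aromatic ring. Among the compounds with values here, no measured pair shows this kind of exchange, so nothing anchors its size. The step is expected to stay within the scatter, estimated as a 1.1-fold lower number from compound 2 to compound 3 (0.03 log units; within the scatter) in this assay. Compound 3 is thus estimated at 3 h, with a range from 1.5 h to 6 h.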

Compound 3, half-life: 3.54 h
Estimate against measurement, compound 3: 1.2-fold (0.07 log units) below; low and high end bracket the measured number.
By their numbers in this assay, from the lowest: compounds 2, 3 and 1 (each within the scatter of the next).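

In this assay, within the data shown here, the exchange of 1-methyl-1H-indol-6-yl for 2,3-dihydro-1H-inden-5-yl gives a 1.1-fold higher number from compound 2 to compound 3 (0.04 log units; within the scatter) and provides the first single-place comparison. At this position on a nitrogen on an aromatic ring, a five-membered aromatic ring with one hetero atom gives way to a non-aromatic, carbon-only five-membered ring with no half-life change beyond the scatter. No available data account for this result.

On these data alone, whether a larger change here would separate from the scatter remains open. A carboxylic acid or a primary amine on the 2,3-dihydro-1H-inden-5-yl group would test this.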